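A few compounds are considered here, and "the series" means these few. Any claim that something is new, unique, unknown or untested is made for them only; others in the source may bear on it.

Measured so far in an assay on RBL-1 cells for inhibition of Polyunsaturated fatty acid 5-lipoxygenase (Rattus norvegicus); on this read-out lower numbers stand for stronger inhibition and higher numbers for weaker inhibition:
compound 1, `CN(O)/C=C\C(=O)c1ccc2ccccc2c1`, gives 1800 nM
compound 2, `CCc1c(N(O)/C=C\C(=O)c2ccc3ccccc3c2)ccc2ccccc12`, gives 750 nM
compound 3, `O=C(/C=C\N(O)Cc1ccc(OCc2ccccc2)cc1)C1CC1`, gives 2600 nM

All three carry the same hydroxylamine-bearing enone motif and differ in the groups around it. Compound 3 has the highest number of the three. Its nearest neighbour is compound 1, whose number lies within the scatter of compound 3, so no order can be read between these two. Compound 2 gives the lowest number, and the gap from compound 3 to compound 2 lies beyond the scatter. Among the measured compounds shown here, no pair of measured compounds differs in a single place; compound 3 differs from compounds 1 and 2 in several places at once, so the three numbers say nothing about any one change on its own.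

Compound 4, `COC(=O)/C=C\N(O)Cc1ccc(OCc2ccccc2)cc1`, is not yet measured. It differs from compound 3 in one place: methoxy in place of cyclopropyl on a carbonyl carbon. Read one bond further out, the cyclopropylcarbonyl becomes a methoxycarbonyl on the ethenyl chain. For the measured compounds named here, nothing among the measured compounds shows this exchange, so the expectation rests on the change alone. The step of a 2.3-fold higher number from compound 3 to compound 4 (0.36 log units; beyond the scatter) is expected to go towards a higher number, beyond the scatter but not by much. For compound 4 an inhibitory concentration of 6000 nM is estimated, with a range from 2000 nM to 20000 nM.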

Compound 4, half-maximal inhibitory concentration: 4800 nM
Compound 4: the middle estimate sits 1.3-fold (0.10 log units) above what was measured, within the range that was stated.
By their numbers in this assay, from the lowest: compound 2; then compounds 1, 3 and 4 (each within the scatter of the next, the first and the last beyond it).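

Among the compounds shown here, compounds 3 and 4 are the first pair to differ in one place, so a single change can now be read on its own. In this assay the exchange of cyclopropyl for methoxy on a carbonyl carbon gives a 1.8-fold higher number from compound 3 to compound 4 (0.27 log units; within the scatter) and so sets no order between the two compounds. At this position, then, a three-membered carbon ring can give way to an open group that contains oxygen and counts one hydrogen-bond acceptor, with no step beyond the scatter, and nothing shown here offers an explanation for that result.

The compounds shown leave open what other groups on this carbonyl carbon would give, such as an amine, a hydroxyl that completes a carboxylic acid, or a longer chain such as ethoxy or butoxy. For the compounds shown here, they also leave open whether the same exchange reads alike on the frameworks of compound 1 and compound 2, and which feature of compound 2 goes with its lower number, since no single-place step links it to any other compound.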